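Estimating compound 4 from three weakly active aryl variants

The compounds below may be only part of what the source reports. "The series", "measured", "known", "first", "only" and "open" are said of these compounds alone.

Measured in a functional assay on A549 cells (Homo sapiens) for antiproliferative activity, read by MTT assay, with a stated time of 48 h; a lower number here means a stronger inhibitor, a higher number a weaker inhibitor:
compound 1, `N#CC1=C(N)Oc2c(c3nc4ccccc4nc3c3ccccc23)C12C(=O)N(Cc1cnnn1-c1ccc(Cl)cc1)c1ccccc12`: > 50000 nM (a limit of the assay)
compound 2, `N#CC1=C(N)Oc2c(c3nc4ccccc4nc3c3ccccc23)C12C(=O)N(Cc1cnnn1-c1ccccc1Cl)c1ccccc12`: 42600 nM
compound 3, `N#CC1=C(N)Oc2c(c3nc4ccccc4nc3c3ccccc23)C12C(=O)N(Cc1cnnn1-c1ccccc1Br)c1ccccc12`: > 50000 nM (a limit of the assay)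

Compound 2 holds the only number shown in this assay; compounds 1 and 3 sit at the limit (the limit of > 50000 nM in this assay, at which 2 of the 3 values shown sit). The steps touching compound 2 are an at least 1.1-fold lower number from compound 1 to compound 2 (0.06 log units; that floor lies within the scatter) and an at least 1.1-fold higher number from compound 2 to compound 3 (0.06 log units; that floor lies within the scatter), both floors lying within the scatter. Compound 4, `Cc1cc(C)cc(-n2nncc2CN2C(=O)C3(C(C#N)=C(N)Oc4c3c3nc5ccccc5nc3c3ccccc43)c3ccccc32)c1`, differs from compound 2 by 3,5-dimethylphenyl in place of 2-chlorophenyl on an aromatic nitrogen. For the measured compounds named here, no measured step tests a change of this kind, and the steps that exist show no movement beyond the scatter. Compound 4 is therefore expected to give 45000 nM, between 18000 nM and 60000 nM. That estimate means a 1.1-fold higher number from compound 2 to compound 4 (0.02 log units; within the scatter), no step beyond the scatter.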

Compound 4, half-maximal inhibitory concentration: > 50000 nM
Compound 4 gave a limit, no number; the forecaster's own chance of this, stated with the estimate: 50%; middle value at least 1.1-fold (0.04 log units) from the limit.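

In this assay, the first non-halogen ring at this aromatic nitrogen, 3,5-dimethylphenyl, brings no gain over 2-chlorophenyl, giving an at least 1.1-fold higher number from compound 2 to compound 4 (0.06 log units; that floor lies within the scatter). The value of compound 4 is a limit of the assay, not a number, so the steps from compound 1 and compound 3 cannot be read, and this change adds a further compound to those at the limit: the limit of > 50000 nM in this assay, at which 3 of the 4 values shown sit.

On these data alone, whether an amine or a carboxylic acid on this phenyl ring would bring a number clearly lower remains open. So does the effect of a longer alkyl chain replacing the ring on this nitrogen.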